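A few compounds are considered here, and "the series" means these few. Any claim that something is new, unique, unknown or untested is made for them only; others in the source may bear on it.

Working notes on the series.

Compound 1 `C=CCOc1ccc2c(NCCCN(C)C)ccnc2c1` carries an allyloxy group and a three-carbon amine chain on the shared core. In a physicochemical assay for solubility (on this read-out lower numbers stand for lower solubility and higher numbers for higher solubility), compound 1 gives > 10000 ug/mL, which is a limit of the assay and not a number. Compound 2 `CCOc1ccc2c(NCCN(C)C)ccnc2c1` has an ethoxy group and a two-carbon amine chain. In this assay compound 2 gives > 10000 ug/mL, again a limit. Compound 3 `CN(C)CCNc1ccnc2cc(OCc3ccccc3)ccc12` replaces the ethoxy group with benzyloxy. In this assay compound 3 gives > 10000 ug/mL, also a limit. The step from compound 2 to compound 3 is therefore a step that the two limits leave unreadable from compound 2 to compound 3.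

Compound 4 `C=CCOc1ccc2c(NCCN(C)C)ccnc2c1` is still to be measured. It differs from compound 3 as follows: vinyl in place of phenyl on a saturated chain carbon bound to an oxygen on an aromatic ring.

Compound 4 sits between compound 1 and compound 2 in structure, both of which, like compound 3, stand at the limit of > 10000 ug/mL in this assay, at which 3 of the 3 values shown sit. For the measured compounds named here, no measured step shows any readable size. Compound 4 is therefore expected to give 15000 ug/mL, with a range from 8000 ug/mL to 40000 ug/mL, most likely reported again only as a limit. The step from compound 3 to compound 4 is expected to be a step that the limit leaves unreadable from compound 3 to compound 4, not readable beyond the limit.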

Compound 4, solubility: > 10000 ug/mL
Compound 4: no number, only a limit (the forecaster's own chance of this, stated with the estimate: 90%); the middle value does not contradict the limit.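

In this assay compound 4 gives > 10000 ug/mL as a limit and not a number, so no step linking it to compound 1, compound 2 or compound 3 can be read: the limit of > 10000 ug/mL in this assay, at which 4 of the 4 values shown sit.

The compounds shown leave open whether any of these four differ at all in this assay as actual numbers.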